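The source may report more compounds than this note shows. Statements on the series, on what has been measured and on what is new or still open speak of the compounds shown alone.

Compound 1 `O=C1C(Nc2ccccc2)=CC(=O)c2c1nc1n2[C@H]2OC[C@@H](O)[C@H]2OC1` is tested in a functional assay on MCF7 cells (Homo sapiens) for inhibition, read by sulforhodamine B assay; a lower number here means a stronger inhibitor, a higher number a weaker inhibitor. In this assay compound 1 gives only the assay limit > 4000 nM. Compound 2 `CCc1ccc(NC2=CC(=O)c3c(nc4n3[C@H]3OC[C@@H](O)[C@H]3OC4)C2=O)cc1` gives 8990 nM in this assay. Compound 3 `O=C1C=C(NC2CCCCC2)C(=O)c2c1nc1n2[C@H]2OC[C@@H](O)[C@H]2OC1` also reaches only a limit in this assay, > 8000 nM.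

Compound 3 therefore stands among the weakest values shown, known only as a limit, with compound 1 also sitting at a limit, the limit of > 8000 nM in this assay, at which 1 of the 3 values shown sits, and the limit of > 4000 nM in this assay, at which 1 of the 3 values shown sits, being the two limits of this set. Compound 4 `CCOc1ccccc1NC1=CC(=O)c2nc3n(c2C1=O)[C@H]1OC[C@@H](O)[C@H]1OC3` is not yet measured. It differs from compound 3 in one place: 2-ethoxyphenyl in place of cyclohexyl on an amine nitrogen.

Within the data shown here, the only measured step, a step that the limit leaves unreadable from compound 1 to compound 2, changes a group on an aromatic ring, not the group on the amine nitrogen, and its size cannot be read; no measured step swaps a cyclohexyl for an aryl group on the amine nitrogen. Both aryl-bearing compounds, compound 1 and compound 2, are weak, as is the cyclohexyl-bearing compound 3. Compound 4 is therefore expected to stay weak in this assay, with an expected step that the limit leaves unreadable from compound 3 to compound 4 not beyond the scatter, and it may well return only a limit. The estimate for compound 4 is 9000 nM, expected to fall between 3000 nM and 30000 nM.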

Compound 4, half-maximal inhibitory concentration: > 4000 nM
Compound 4 ended at the assay's limit; the forecaster's own chance of this, stated with the estimate: 50%; the middle value does not contradict the limit.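

In this assay compound 4 gives only a limit, > 4000 nM, and with compound 3 also known only as a limit, the step between these two compounds cannot be read. The compounds shown leave open whether 2-ethoxyphenyl in place of cyclohexyl on an amine nitrogen changes inhibition at all.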